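The source may hold more compounds than are shown below. What is called first, only, known or untested is meant among the compounds shown, and "the series" means these compounds.

Measured compounds:
- compound 1, `CCCOC(=O)N1CCN(/[N+]([O-])=N/Oc2cc(O/N=[N+](\[O-])N(C)C)c([N+](=O)[O-])cc2[N+](=O)[O-])CC1`: 3900 nM
- compound 2, `CN(C)/[N+]([O-])=N/Oc1cc(O/N=[N+](\[O-])N2CCCCC2)c([N+](=O)[O-])cc1[N+](=O)[O-]`: 4900 nM

In a functional assay on HL-60 cells (Homo sapiens) for antiproliferative activity, read by MTT assay, with a stated time of 72 h (on this read-out lower numbers stand for stronger inhibition of growth and higher numbers for weaker inhibition of growth), compound 1 gives 3900 nM and compound 2 gives 4900 nM. On these two numbers compound 2 cannot be set apart from compound 1: the gap between them lies within the scatter, so the two read as equally active in this assay. Going by the values given here, no pair of measured compounds differs in one place only, so no single structural step has a measured size.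

Compound 3, `CN(C)/[N+]([O-])=N/Oc1cc(O/N=[N+](\[O-])N2CCCC2)c([N+](=O)[O-])cc1[N+](=O)[O-]`, is not yet measured. It differs from compound 2 by the change (pyrrolidin-1-yl in place of piperidin-1-yl on a double-bonded nitrogen). Nothing in the measured pair speaks to a ring contraction of this kind; the two measured compounds differ at several places at once and still land within the scatter of each other. The step from compound 2 to compound 3 is therefore expected to be small, with no direction beyond the scatter: a 1.1-fold lower number from compound 2 to compound 3 (0.04 log units; within the scatter) is the estimated step. For compound 3 the expected value in this assay is 4500 nM, with a range from 2000 nM to 10000 nM.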

Compound 3, concentration for total growth inhibition: 4900 nM
The estimate for compound 3 lay 1.1-fold (0.04 log units) below the measured number; low and high end bracket the measured number.
By their numbers in this assay, from the lowest: compounds 1, 2 and 3 (each within the scatter of the next).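

In this assay, going by these compounds alone, pyrrolidin-1-yl in place of piperidin-1-yl on a double-bonded nitrogen gives no change at the digits printed from compound 2 to compound 3 (within the scatter), and this is the first step with a measured size. The earlier pair differs at several places at once, so it could not isolate this place; the new pair shows that, with the rest of the structure held constant, a five-membered non-aromatic ring and a six-membered one read alike here. No available data bear on why the two rings read alike.

On these data alone, the reading so far covers only these two saturated rings, so it remains open whether a morpholine ring, a seven-membered azepane ring or an open-chain diethylamino group at this place would also read alike, or whether an amine or carboxylic acid carried on the ring would shift the number beyond the scatter. As far as these compounds go, it is also open whether the same ring change would read alike in a compound carrying a group other than dimethylamino on the second double-bonded nitrogen, such as the propyl carbamate piperazine of compound 1.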